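Swapping methoxy for chloro: a cytotoxicity estimate

The source may hold more compounds than are shown below. What is called first, only, known or untested is meant among the compounds shown, and "the series" means these compounds.

Measured in an ADME assay on PC-12 cells (Rattus norvegicus) for cytotoxicity, read by MTT assay, with a stated time of 24 h; a higher number here means that more compound is tolerated, a lower number that less compound is tolerated:
- compound 1 `Cc1c(C(=O)OCC#CCN2CCN(c3ccc(Br)cc3C#N)CC2)sc2ncnc(N3CCCCC3)c12`: 136 ug/mL
- compound 2 `COc1ccc(-c2nnc(-c3sc4ncnc(N5CCCCC5)c4c3C)o2)cc1`: 124 ug/mL

These two values lie within the usual scatter of each other, so neither compound stands apart. Compound 3 `Cc1c(-c2nnc(-c3ccc(Cl)cc3)o2)sc2ncnc(N3CCCCC3)c12` changes compound 2 in one place, 4-methoxyphenyl to 4-chlorophenyl: chloro in place of methoxy on an aromatic carbon. Going by the values given here, no measured pair differs in one place, so no direct precedent exists for this swap. In this assay, no shift beyond the scatter is expected, and the estimate stays close to compound 2 at 124 ug/mL. The expected size of the change is small, a 1.0-fold lower number from compound 2 to compound 3 (0.01 log units; within the scatter). Compound 3 is estimated at 120 ug/mL, with an expected range of 60 ug/mL to 230 ug/mL.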

Compound 3, half-maximal cytotoxic concentration: 151 ug/mL
Compound 3: the middle estimate sits 1.3-fold (0.10 log units) below what was measured, and the stated range covers the measured number.
By their numbers in this assay, from the lowest: compounds 2, 1 and 3 (each within the scatter of the next).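

In this assay, going by these compounds alone, replacing 4-methoxyphenyl with 4-chlorophenyl gives a 1.2-fold higher number from compound 2 to compound 3 (0.09 log units; within the scatter), the first direct comparison at this position. On this evidence, chloro in place of methoxy, para to a large group, leaves the two compounds indistinguishable. Nothing measured here explains this result. The compounds shown leave open whether an amine or a carboxylic acid at the same place would also stay within the scatter. They also leave open whether the same swap would behave this way on another core.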